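This account rests on a few compounds, and the source may have more. Where it says the series, first, only, none or still open, it means among the compounds named here.

Measured in a functional assay on UO-31 cells (Homo sapiens) for inhibition, read by sulforhodamine B assay, with a stated time of 48 h, tested at 10 uM; a higher number here means more inhibition at the concentration tested (going by the name of the read-out), a lower number less inhibition:
Compound 1, `Fc1ccc(-c2cn3ccnc3c(-c3ccc4ncn(C5CCCCC5)c4c3)n2)cc1`, gives 37.8%.
Compound 2, `Fc1ccccc1-c1cn2ccnc2c(-c2ccc3ncn(C4CCCCC4)c3c2)n1`, gives 22.9%.

Compound 2 stands lowest of the two numbers in this assay; its nearest neighbour is compound 1, and the step of a number 14.9 percentage points lower from compound 1 to compound 2 (beyond the scatter) lies beyond the scatter. Among the compounds with values here, that step, a modest drop, is the only measured step in the set, and it comes from moving a single fluorine on the phenyl ring.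

Compound 3, `FC(F)(F)c1cccc(-c2cn3ccnc3c(-c3ccc4ncn(C5CCCCC5)c4c3)n2)c1`, carries the change (3-(trifluoromethyl)phenyl in place of 2-fluorophenyl on an aromatic carbon). This brings a 3-(trifluoromethyl)phenyl where compound 2 held a 2-fluorophenyl, so both the group and its position on the phenyl ring differ. Within the data shown here, the step from compound 1 to compound 2 shows that changing the position of one fluorine can shift the read-out beyond the scatter, but no measured pair compares a trifluoromethyl with a fluorine, and the direction for compound 3 cannot be read from the data. The expected step is therefore a number 7.1 percentage points higher from compound 2 to compound 3 (within the scatter), a small rise that stays close to the scatter. For compound 3 the estimated value in this assay is 30%, with a range from 8% to 55%.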

Compound 3, a percentage reported as inhibition, at one concentration (the size of the read-out at that concentration, not a potency): 22.5%
Compound 3: the middle estimate sits 7.5 percentage points above what was measured; the range from low to high includes it.
By their numbers in this assay, from the lowest: compounds 3 and 2 (each within the scatter of the next); then compound 1.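

The data give a number 0.4 percentage points lower from compound 2 to compound 3 (within the scatter) in this assay when 3-(trifluoromethyl)phenyl replaces 2-fluorophenyl, so at this carbon of the shared core, a change in both the group and its place on the phenyl ring leaves no difference that can be told from the scatter. Against 4-fluorophenyl the data give a number 15.3 percentage points lower from compound 1 to compound 3 (beyond the scatter) and, with the earlier drop, compound 1 now stands above two other substituted phenyl groups rather than one, with neither of the three compounds going against this. Nothing available explains why compound 1 stands apart from compound 2 and compound 3.

Every group shown at this carbon is a phenyl ring carrying fluorine, and the pair of compound 2 and compound 3 cannot separate the group from its place on that ring. From the compounds shown here alone, whether an unsubstituted phenyl, or a phenyl bearing an amine or a carboxylic acid, would read like compound 1 or like compound 2 and compound 3 remains open.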